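A few compounds are considered here, and "the series" means these few. Any claim that something is new, unique, unknown or untested is made for them only; others in the source may bear on it.

Compound 3 `C=CCN(C)C(=O)c1ccc(C(CC)(CC)c2ccc(OCC(=O)C(C)(C)C)c(C)c2)n1CC` stands at the high end of the three numbers in an assay on HL-60 cells for agonist activity at vitamin D3 receptor (Homo sapiens), read by microscopy, with a stated time of 96 h (on this read-out higher numbers stand for an effect only at larger amounts of compound and lower numbers for an effect already at smaller amounts), where compound 3 gives 21600 nM. Compound 1 `CCn1c(C(=O)NCCN(C)C)ccc1C(CC)(CC)c1ccc(OCC(=O)C(C)(C)C)c(C)c1` gives 77 nM in this assay, and compound 2 `CCn1c(C(=O)NCCCN(C)C)ccc1C(CC)(CC)c1ccc(OCC(=O)C(C)(C)C)c(C)c1` gives 96 nM; the step of a 1.2-fold higher number from compound 1 to compound 2 (0.10 log units; within the scatter) is within the scatter. The steps of a 280-fold higher number from compound 1 to compound 3 (2.45 log units; beyond the scatter) and a 230-fold higher number from compound 2 to compound 3 (2.35 log units; beyond the scatter) are large and both replace a (dimethylamino)alkylamino group on the carbonyl carbon with allyl(methyl)amino. Going by the values given here, compound 4 `CCn1c(C(=O)N(C)c2ccccc2)ccc1C(CC)(CC)c1ccc(OCC(=O)C(C)(C)C)c(C)c1` differs from compound 3 by phenyl in place of allyl on an amide-type nitrogen; the amide stays tertiary and no amine group returns, so none of the measured steps bears on this change directly, and for this assay a shift within the scatter is expected, as a 1.1-fold lower number from compound 3 to compound 4 (0.03 log units; within the scatter). Compound 4 is therefore estimated at 20000 nM, with a range from 5000 nM to 80000 nM.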

Compound 4, half-maximal effective concentration: 18500 nM
For compound 4 the middle estimate is 1.1-fold (0.03 log units) above the measured one, and the stated range covers the measured number.
By their numbers in this assay, from the lowest: compounds 1 and 2 (each within the scatter of the next); then compounds 4 and 3 (each within the scatter of the next).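

In this assay, phenyl in place of allyl on the amide-type nitrogen gives a step within the scatter (a 1.2-fold lower number from compound 3 to compound 4 (0.07 log units; within the scatter)). With a second group, methyl(phenyl)amino on the carbonyl carbon also reads far higher than both dimethylamino-bearing amides (a 190-fold higher number from compound 2 to compound 4 (2.28 log units; beyond the scatter)) (a 240-fold higher number from compound 1 to compound 4 (2.38 log units; beyond the scatter)). No measurement on hand gives a reason for these steps.

The amide hydrogen and the dimethylamino group leave together in compound 3 and compound 4, so their contributions remain unseparated. A propylamino group or a (2-(dimethylamino)ethyl)(methyl)amino group on the carbonyl carbon would take them apart.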